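Working notes on cytotoxicity in a small series

This account rests on a few compounds, and the source may have more. Where it says the series, first, only, none or still open, it means among the compounds named here.

Compound 1 `COc1ccc2[nH]c(=O)c(-c3nc4cc(F)ccc4[nH]3)cc2c1` gives in a functional assay on HepG2 cells (Homo sapiens) for cytotoxicity, read by MTT assay, with a stated time of 48 h (a lower number here means a stronger inhibitor, a higher number a weaker inhibitor), a value of > 100000 nM, which is a limit of the assay.
Compound 2 `COc1ccc2[nH]c(=O)c(-c3nc4cc(Cl)ccc4[nH]3)cc2c1` gives in this assay a value of > 100000 nM, again a limit.
Compound 3 `Cc1ccc2[nH]c(=O)c(-c3nc4ccccc4[nH]3)cc2c1` gives in this assay a value of > 100000 nM, also a limit.

Compound 3 therefore stands at the limit, as do the other two values shown, (the limit of > 100000 nM in this assay, at which 3 of the 3 values shown sit). For the measured compounds named here, the one measured step, a step that the two limits leave unreadable from compound 1 to compound 2, runs between two limits and has no readable size. Compound 4 `COc1ccc2[nH]c(=O)c(-c3nc4ccccc4[nH]3)cc2c1` differs from compound 3 by methoxy in place of methyl on an aromatic carbon. Going by the values given here, no measured step concerns a methyl-to-methoxy exchange; the only step recorded is the chloro-for-fluoro swap from compound 1 to compound 2, which is itself unreadable. No shift in this assay beyond the scatter can be expected from compound 3 to compound 4, and the estimated step is a number no higher from compound 3 to compound 4 (the limit leaves the size open). Compound 4 is expected to sit at 100000 nM in this assay, within a range of 50000 nM to 300000 nM, most likely reported once more as a limit.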

Compound 4, half-maximal inhibitory concentration: > 100000 nM
Compound 4: only a limit was reported; the forecaster's own chance of this, stated with the estimate: 85%; the middle value lies on the limit itself.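

No new step can be read between compound 4 and compound 1, compound 2 or compound 3 in this assay: the limit of > 100000 nM in this assay, at which 4 of the 4 values shown sit.

The compounds shown leave open how far each of the four lies from that limit, and whether any exchange on the shared core changes cytotoxicity.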